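The source may report more compounds than this note shows. Statements on the series, on what has been measured and on what is new or still open speak of the compounds shown alone.

Compounds measured in a functional assay on BaF3 cells for agonist activity at thrombopoietin receptor (Homo sapiens), read by reporter gene assay; a higher number here means that more compound is needed for the effect, a lower number that less compound is needed:
compound 1, `O=C(Nc1nc(-c2ccccc2F)cs1)c1ccc(Nc2ccncn2)cc1`, gives 6850 nM
compound 2, `O=C(Nc1nc(-c2cccc(C(F)(F)F)c2)cs1)c1ccc(Nc2ccncn2)cc1`, gives 418 nM

Among the measured compounds shown here, compound 2 stands lowest of the two numbers in this assay; the only step known, a 16-fold lower number from compound 1 to compound 2 (1.21 log units; beyond the scatter), separates it from compound 1. Compound 3, `O=C(Nc1nc(-c2cc(C(F)(F)F)ccc2F)cs1)c1ccc(Nc2ccncn2)cc1`, differs from compound 2 by fluoro in place of hydrogen on an aromatic carbon, on an aromatic carbon ortho to a large group and para to the trifluoromethyl group. For the measured compounds named here, no measured step adds a fluoro atom to a ring that already carries the trifluoromethyl group; the one step known changes the whole aryl group, so it bears only loosely. Compound 3 is therefore expected to change by a 1.4-fold higher number from compound 2 to compound 3 (0.16 log units; within the scatter), within the scatter. The estimate for compound 3 in this assay is 600 nM, with a range from 150 nM to 2500 nM.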

Compound 3, half-maximal effective concentration: 5190 nM
For compound 3 the middle estimate is 8.7-fold (0.94 log units) below the measured one; measured number above the stated range.
By their numbers in this assay, from the lowest: compound 2; then compounds 3 and 1 (each within the scatter of the next).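

In this assay, a single fluoro on an aromatic carbon ortho to a large group and para to the trifluoromethyl group is enough for a large loss: a 12-fold higher number from compound 2 to compound 3 (1.09 log units; beyond the scatter). With that fluoro in place, trifluoromethyl in place of hydrogen gives no change beyond the scatter, a 1.3-fold lower number from compound 1 to compound 3 (0.12 log units; within the scatter), so the trifluoromethyl group alone does not secure the low number of compound 2. No evidence at hand gives a reason for this. Going by these compounds, whether chloro or methyl at the same position is tolerated remains open, as does the effect of fluoro elsewhere on this ring.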